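Shared core: furan-2-yl in place of the phenyl

The source may hold more compounds than are shown below. What is called first, only, known or untested is meant among the compounds shown, and "the series" means these compounds.

Measured so far in a functional assay on HepG2 cells (Homo sapiens) for inhibition, read by MTT assay, with a stated time of 24 h; a higher number here means a weaker inhibitor, a lower number a stronger inhibitor:
compound 1 `CCOC(=O)c1c(C)[nH]c(=O)c(C#N)c1-c1ccccc1` — 38500 nM
compound 2 `CCOC(=O)c1c(C)[nH]c(=O)c(C#N)c1-c1ccc(Br)cc1` — 65500 nM
compound 3 `CCOC(=O)c1c(C)[nH]c(=O)c(C#N)c1-c1ccccc1Cl` — 34100 nM

All three numbers lie within the scatter of one another. Compound 1 sits nearest to compound 3, a 1.1-fold lower number from compound 1 to compound 3 (0.05 log units; within the scatter), and furthest from compound 2, a 1.7-fold higher number from compound 1 to compound 2 (0.23 log units; within the scatter); the remaining pair, a 1.9-fold lower number from compound 2 to compound 3 (0.28 log units; within the scatter), is likewise within the scatter.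

Compound 4 `CCOC(=O)c1c(C)[nH]c(=O)c(C#N)c1-c1ccco1` differs from compound 1 by furan-2-yl in place of phenyl on an aromatic carbon. The measured steps bear only loosely on this: each of them keeps the phenyl and adds or moves a halogen on it, and none exchanges the ring itself for a five-membered one with a hetero atom. What they do show is that changes at this position of the shared core have so far stayed within the scatter. On that basis no step beyond the scatter is expected in this assay for compound 4 in either direction, and compound 4 is estimated at 40000 nM, with a range from 15000 nM to 110000 nM. The expected step is a 1.0-fold higher number from compound 1 to compound 4 (0.02 log units; within the scatter).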

Compound 4, half-maximal inhibitory concentration: 57400 nM
Beside the measured number, compound 4's estimate is 1.4-fold (0.16 log units) below it; low and high end bracket the measured number.
By their numbers in this assay, from the lowest: compounds 3, 1, 4 and 2 (each within the scatter of the next).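

In this assay, the position opposite the ring nitrogen accepts an exchange of the ring itself, not only a halogen on the phenyl, without a step beyond the scatter: furan-2-yl in place of phenyl gives a 1.5-fold higher number from compound 1 to compound 4 (0.17 log units; within the scatter) as its whole effect. Furan-2-yl, which brings a ring oxygen and a hydrogen-bond acceptor that phenyl lacks, also stays within the scatter of both halogenated phenyl compounds, with a 1.7-fold higher number from compound 3 to compound 4 (0.23 log units; within the scatter) for the exchange from 2-chlorophenyl and a 1.1-fold lower number from compound 2 to compound 4 (0.06 log units; within the scatter) for the exchange from 4-bromophenyl. No supporting data bear on the reason for these small steps.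

Open, going by these compounds, is whether an aminomethyl group, a carboxylic acid or a longer alkyl chain at this position would give a step beyond the scatter. Also open, on these data alone, is how the series responds to exchanging the nitrile or the ethoxycarbonyl group on the shared core.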